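This account rests on a few compounds, and the source may have more. Where it says the series, first, only, none or still open, it means among the compounds named here.

Compound 3 `O=Cc1ccc(-c2cn3ccnc3c(-c3ccc4ncn(Cc5ccccc5)c4c3)n2)cc1` gives 17.5% in a functional assay on HT-29 cells (Homo sapiens) for inhibition, read by sulforhodamine B assay, with a stated time of 48 h, tested at 10 uM (on this read-out higher numbers stand for more inhibition at the one concentration tested (going by the name of the read-out) and lower numbers for less inhibition), the lowest of the three numbers recorded for this series. Compound 2 `Cc1cccc(-c2cn3ccnc3c(-c3ccc4ncn(Cc5ccccc5)c4c3)n2)c1` stands nearest, giving 42% in this assay, and compound 1 `CCc1ccc(-c2cn3ccnc3c(-c3ccc4ncn(Cc5ccccc5)c4c3)n2)cc1` stands furthest, giving 68.8% in this assay. Both gaps lie beyond the scatter: a number 24.5 percentage points lower from compound 2 to compound 3 (beyond the scatter) and a number 51.3 percentage points lower from compound 1 to compound 3 (beyond the scatter).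

Compound 4 `c1ccc(Cn2cnc3ccc(-c4nc(-c5cccc6ccccc56)cn5ccnc45)cc32)cc1` differs from compound 3 in one place: naphthalen-1-yl in place of 4-formylphenyl on an aromatic carbon. The group that leaves carries the formyl and its single hydrogen-bond acceptor; the group that enters is carbon only.

Among the measured compounds shown here, two measured steps bear on this change. The step of a number 51.3 percentage points lower from compound 1 to compound 3 (beyond the scatter) shows a large loss of inhibition when formyl replaces ethyl, and the step of a number 24.5 percentage points lower from compound 2 to compound 3 (beyond the scatter) shows a modest loss when 4-formylphenyl replaces 3-methylphenyl. Both point the same way: the compound carrying 4-formylphenyl gives the least inhibition, and the two compounds carrying a hydrocarbon aryl give more. Naphthalen-1-yl is also carbon only, though larger than either of those groups, and no measured compound carries it, so the size of its effect is uncertain.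

Compound 4 is therefore expected to rise in this assay, a number 30.5 percentage points higher from compound 3 to compound 4 (beyond the scatter). The estimate for compound 4 is 48%, with a range from 22% to 74%.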

Compound 4, a percentage reported as inhibition, at one concentration (the size of the read-out at that concentration, not a potency): 18.6%
Estimate against measurement, compound 4: 29.4 percentage points above; the whole stated range lies above it.
By their numbers in this assay, from the lowest: compounds 3 and 4 (each within the scatter of the next); then compound 2; then compound 1.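

In this assay, a carbon-only group at this position does not by itself give more inhibition: naphthalen-1-yl in place of 4-formylphenyl gives a number 1.1 percentage points higher from compound 3 to compound 4 (within the scatter), so compound 3 and compound 4 cannot be told apart. The earlier compounds shown here linked higher numbers to a hydrocarbon aryl group, but that link holds only for 3-methylphenyl and 4-ethylphenyl, and compound 4 goes against it, with a number 23.4 percentage points lower from compound 2 to compound 4 (beyond the scatter) and a number 50.2 percentage points lower from compound 1 to compound 4 (beyond the scatter). No measurement at hand accounts for why this two-ring group and the formyl-bearing ring read within the scatter of each other here.

The compounds shown leave open whether the second ring of naphthalen-1-yl, its point of attachment or some other feature sets compound 4 apart from compound 1 and compound 2, and a naphthalen-2-yl group or a plain phenyl ring would bear on that question. They also leave open how far a longer chain such as 4-propylphenyl, or an amine or a carboxylic acid on the phenyl ring, would carry the trend, given that 3-methylphenyl and 4-ethylphenyl differ both in their chain and in where it sits.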